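Dimethylamino in place of nitro: notes on compound 3

The compounds below may be only part of what the source reports. "The series", "measured", "known", "first", "only" and "open" are said of these compounds alone.

Values so far (an ADME assay on J774.A1 cells (Mus musculus) for cytotoxicity, read by MTT assay, with a stated time of 48 h; on this read-out higher numbers stand for lower toxicity in this test and lower numbers for higher toxicity in this test)
- compound 1 (`C/C(=C\c1ccc([N+](=O)[O-])cc1)C(=O)/C=C/c1ccccc1`): 47300 nM
- compound 2 (`C/C(=C\c1ccc([N+](=O)[O-])cc1)C(=O)/C=C/c1ccc([N+](=O)[O-])cc1`): 43000 nM

Among the compounds with values here, compound 2 gives 43000 nM and has only one measured neighbour. The step between the two (a 1.1-fold lower number from compound 1 to compound 2 (0.04 log units; within the scatter)) does not separate them.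

The next change leads to compound 3 (`C/C(=C\c1ccc([N+](=O)[O-])cc1)C(=O)/C=C/c1ccc(N(C)C)cc1`), with dimethylamino in place of nitro on an aromatic carbon, para to a large group (dimethylamino in place of nitro on an aromatic carbon).

Within the data shown here, only that one measured step bears on this change. It put nitro in place of hydrogen on an aromatic carbon and left the numbers level within the scatter. Among the measured compounds shown here, no compound measured so far carries dimethylamino, so the data give neither a size nor a direction for the new step. On this thin evidence, no shift beyond the scatter is expected in this assay, though the uncertainty is wide.

The estimated move is small (a 1.1-fold lower number from compound 2 to compound 3 (0.03 log units; within the scatter)) and rests on a single step.

The expected value for compound 3 is 40000 nM (estimated range 14000 nM to 100000 nM).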

Compound 3, half-maximal cytotoxic concentration: 24700 nM
Compound 3: the middle estimate sits 1.6-fold (0.21 log units) above what was measured; low and high end bracket the measured number.
By their numbers in this assay, from the lowest: compounds 3, 2 and 1 (each within the scatter of the next).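

In this assay, the aromatic position para to a large group has now held hydrogen, nitro and dimethylamino, and the exchange of nitro for dimethylamino gives a 1.7-fold lower number from compound 2 to compound 3 (0.24 log units; within the scatter) as its step. Measured against hydrogen at the same position, dimethylamino gives a 1.9-fold lower number from compound 1 to compound 3 (0.28 log units; within the scatter) as its step, so neither group is separated from hydrogen here, and the two groups are not separated from each other. The series therefore shows that two further exchanges at this position, not only the earlier one of hydrogen for nitro, stay inside the scatter of this read-out, while no accompanying measurement offers an explanation for the numbers.

Going by these compounds, whether any other group at this position, such as a carboxylic acid, a primary amine or a longer chain, would take the number beyond the scatter remains open. The compounds shown also leave open how far the number depends on the nitro group that all of them share, since that group stays unchanged across compound 1, compound 2 and compound 3.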